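Two nitro-bearing acids and a hydroxy analogue

A few compounds are considered here, and "the series" means these few. Any claim that something is new, unique, unknown or untested is made for them only; others in the source may bear on it.

Of the compounds shown here, two have been measured in a physicochemical assay for solubility (a higher number here means a more soluble compound, a lower number a less soluble compound), so far. Compound 1, `O=C(O)c1ccc(C(=O)/C(=C\c2ccc(F)c([N+](=O)[O-])c2)SCc2ccc(F)cc2)cc1`, and compound 2, `O=C(O)c1ccc(C(=O)/C(=C\c2ccc(F)cc2[N+](=O)[O-])SCc2ccc(Br)cc2)cc1`, share one core and differ only in the ring on the sulfur side and in where the fluorine and nitro groups sit on the ring at the double bond. In this assay compound 1 reports only a limit, < 1000 ug/mL, not a number. Compound 2 likewise reports only a limit in this assay, < 1000 ug/mL. Going by the values given here, compound 2 thus stands at the same limit as the only other value, as summarised by the limit of < 1000 ug/mL in this assay, at which 2 of the 2 values shown sit, so no ordering between the two can be read from this assay.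

Compound 3, `O=C(O)c1ccc(C(=O)/C(=C\c2ccc(O)c([N+](=O)[O-])c2)SCc2ccc(Br)cc2)cc1`, is not yet measured. It differs from compound 2 in one place: 4-hydroxy-3-nitrophenyl in place of 4-fluoro-2-nitrophenyl on a double-bonded chain carbon bound to a double-bonded chain carbon. Among the compounds with values here, with no step between measured compounds available, there is no basis for expecting a large move in either direction, so compound 3 is expected to land close to where compound 2 does, within the scatter, as stated by a step that the limit leaves unreadable from compound 2 to compound 3. The estimate for compound 3 in this assay is 300 ug/mL, within a range from 60 ug/mL to 1000 ug/mL, with a real chance that only a limit is again reported.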

Compound 3, solubility: < 1000 ug/mL
Compound 3: a limit, no number (the forecaster's own chance of this, stated with the estimate: 55%); the middle value does not contradict the limit.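

Compound 3, like compound 2, gives only a limit and not a number in this assay, so no step between these two compounds can be read: the limit of < 1000 ug/mL in this assay, at which 3 of the 3 values shown sit.

The compounds shown leave open where any of the three truly sits in this assay, and so whether 4-hydroxy-3-nitrophenyl in place of 4-fluoro-2-nitrophenyl moves the read-out at all.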